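The source may report more compounds than this note shows. Statements on the series, on what has been measured and on what is new or still open speak of the compounds shown alone.

Measured in a functional assay on HepG2 cells (Homo sapiens) for inhibition, read by MTT assay, with a stated time of 48 h; on this read-out lower numbers stand for stronger inhibition and higher numbers for weaker inhibition:
- Compound 1 `CCOC(=O)C1=C(N/N=C(/C(=O)Br)c2ccc(Br)cc2)Nc2[nH]nc(C)c2C1c1ccc(N(C)C)cc1`: 65000 nM
- Compound 2 `CCOC(=O)C(=NNC1=C(C(=O)OCC)C(c2ccc(N(C)C)cc2)c2c(C)n[nH]c2N1)C(=O)OCC`: 80800 nM

For the measured compounds named here, compound 2, at 80800 nM, stands within the scatter of the only other measured compound, so the two cannot be ranked. Compound 3 `CCOC(=O)C1=C(N/C=N/c2ccc(C)cc2)Nc2[nH]nc(C)c2C1c1ccc(N(C)C)cc1` differs from it as follows: a group of 9 heavy atoms (8 carbon, 1 nitrogen; one six-membered aromatic ring of carbon only) in place of a group of 12 heavy atoms (7 carbon, 1 nitrogen, 4 oxygen; no ring), on an amine nitrogen. Going by the values given here, the one measured step bearing on this, a 1.2-fold higher number from compound 1 to compound 2 (0.09 log units; within the scatter), also exchanged a group on an amine nitrogen, and a group with a six-membered aromatic ring of carbon only gave way to one with no ring. Compound 3 brings such a ring back, so no change beyond the scatter is expected in this assay. The expected change is a 1.3-fold lower number from compound 2 to compound 3 (0.13 log units; within the scatter). For compound 3 the estimated value is 60000 nM, with an expected range of 25000 nM to 130000 nM.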

Compound 3, half-maximal inhibitory concentration: 44400 nM
Compound 3: the middle estimate sits 1.4-fold (0.13 log units) above what was measured, and the stated range covers the measured number.
By their numbers in this assay, from the lowest: compounds 3, 1 and 2 (each within the scatter of the next).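

In this assay the amine nitrogen now carries a third kind of group, one with a six-membered aromatic ring of carbon only and no oxygen, and both new steps stay within the scatter (a 1.8-fold lower number from compound 2 to compound 3 (0.26 log units; within the scatter) and a 1.5-fold lower number from compound 1 to compound 3 (0.17 log units; within the scatter)). The three groups at this position therefore cannot be ranked, with or without a ring. No measurement given here accounts for this. From the compounds shown here alone, whether a carboxylic acid or a primary amine on this nitrogen would move the number beyond the scatter remains open.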